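Swapping the ring on the side chain of a shared core

This account rests on a few compounds, and the source may have more. Where it says the series, first, only, none or still open, it means among the compounds named here.

Measured so far:
- compound 1, `CN(CCC#N)C[C@H]1CN(c2ccc(-n3cc(-c4ccccn4)cn3)c(F)c2)C(=O)O1`: 64500 nM
- compound 2, `O=C1O[C@@H](CN2CCC(O)CC2)CN1c1ccc(-n2cc(-c3ccccn3)cn2)c(F)c1`: 45900 nM
- compound 3, `O=C1CCC(=O)N1C[C@H]1CN(c2ccc(-n3cc(-c4ccccn4)cn3)c(F)c2)C(=O)O1`: 45300 nM

All three compounds share one core and differ only in the group carried on a saturated chain carbon bound to a saturated ring carbon. In a physicochemical assay for solubility, read by HPLC, with a stated time of 24 h (a higher number here means a more soluble compound, a lower number a less soluble compound), compound 1 gives 64500 nM, compound 2 gives 45900 nM and compound 3 gives 45300 nM. Compound 3 sits close to both companions: the step of a 1.0-fold lower number from compound 2 to compound 3 (0.01 log units; within the scatter) and the step of a 1.4-fold lower number from compound 1 to compound 3 (0.15 log units; within the scatter) each stay within the scatter, so the three numbers cannot be told apart.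

Compound 4, `O=C1O[C@@H](Cn2ccnc2)CN1c1ccc(-n2cc(-c3ccccn3)cn2)c(F)c1`, is the next member and is not yet measured. It differs from compound 3 in one place: 1H-imidazol-1-yl in place of 2,5-dioxopyrrolidin-1-yl on a saturated chain carbon bound to a saturated ring carbon. Going by the values given here, every change made at this position so far, including a 1.4-fold lower number from compound 1 to compound 2 (0.15 log units; within the scatter), has left the solubility where it was. On that record a further swap of the group at the same place is expected to do the same, so compound 4 is expected to show a 1.1-fold higher number from compound 3 to compound 4 (0.04 log units; within the scatter). The estimate for compound 4 is therefore 50000 nM, with a range from 25000 nM to 100000 nM.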

Compound 4, solubility: 12300 nM
Beside the measured number, compound 4's estimate is 4.1-fold (0.61 log units) above it, and the stated range ends above it.
By their numbers in this assay, from the lowest: compound 4; then compounds 3, 2 and 1 (each within the scatter of the next).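

In this assay this position no longer looks silent: the step of a 3.7-fold lower number from compound 3 to compound 4 (0.57 log units; beyond the scatter) lies beyond the scatter, and so do a 3.7-fold lower number from compound 2 to compound 4 (0.57 log units; beyond the scatter) and a 5.2-fold lower number from compound 1 to compound 4 (0.72 log units; beyond the scatter), while the three earlier compounds could not be told apart. The counts of hydrogen-bond donors and acceptors are the same for 2,5-dioxopyrrolidin-1-yl and 1H-imidazol-1-yl, so those counts do not separate compound 3 from compound 4; what does differ is that a five-membered aromatic ring with 2 hetero atoms enters where a five-membered non-aromatic ring with 1 hetero atom and 2 double bonds outside aromatic rings leaves. No measurement available here accounts for the lower number of compound 4.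

The compounds shown leave open whether another aromatic ring at the same place, such as 1H-pyrazol-1-yl or phenyl, would fall with compound 4 or with the other three. They also leave open how a carboxylic acid or a primary amine on that saturated chain carbon would read in this assay.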